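Swapping the Aromatic Ring on a Shared Core

The compounds below may be only part of what the source reports. "The series", "measured", "known", "first", "only" and "open" are said of these compounds alone.

Compound 1 `CC1=CC[C@H](C(C)(C)NC(=S)NN)CC1`: > 100000 nM
Compound 2 `CC1=CC[C@H](C(C)(C)NC(=S)N/N=C/c2ccc(F)cc2)CC1`: > 100000 nM

In a functional assay on NCI/ADR-RES cells (Homo sapiens) for inhibition, read by sulforhodamine B assay, with a stated time of 48 h (a lower number here means a stronger inhibitor of growth, a higher number a weaker inhibitor of growth), compound 1 reaches only a limit, > 100000 nM. In this assay compound 2 likewise reaches only a limit, > 100000 nM. Compound 2 therefore stands at the limit of this assay, without a number of its own. Compound 3 `CC1=CC[C@H](C(C)(C)NC(=S)N/N=C/c2cccs2)CC1` differs from compound 2 by thiophen-2-yl in place of 4-fluorophenyl on a carbon with a double bond to nitrogen. Among the measured compounds shown here, no step between measured compounds exists here, and both measured values rest at the limit of > 100000 nM in this assay, at which 2 of the 2 values shown sit, so no movement beyond the scatter is expected. The step of a number no higher from compound 2 to compound 3 (the limit leaves the size open) is estimated to be essentially none. Compound 3 is expected to give about 100000 nM, within 30000 nM to 300000 nM.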

Compound 3, concentration for total growth inhibition: 41000 nM
For compound 3 the middle estimate is 2.4-fold (0.39 log units) above the measured one; the measured number falls inside the stated range.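

In this assay, among the compounds shown here, thiophen-2-yl in place of 4-fluorophenyl gives an at least 2.4-fold lower number from compound 2 to compound 3 (0.38 log units; beyond the scatter) and is the first change here to yield a measured number instead of a limit. The group on the carbon with a double bond to nitrogen can therefore shift the reading, and the full addition gives an at least 2.4-fold lower number from compound 1 to compound 3 (0.38 log units; beyond the scatter) as well. Going by these compounds, compound 1 and compound 2 stand only at limits, so the true size of both steps stays open. On these data alone, whether other rings behave like thiophen-2-yl also stays open, for instance furan-2-yl or a phenyl ring carrying an amine or a carboxylic acid.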